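This account rests on a few compounds, and the source may have more. Where it says the series, first, only, none or still open, it means among the compounds named here.

Two compounds from this series share one core. Compound 1 `COc1ccc(-c2cc(/C=C/C(=O)c3ccc(N)cc3)[nH]n2)cc1` carries a single methoxy on its outer ring, while compound 2 `COc1cc(-c2cc(/C=C/C(=O)c3ccc(N)cc3)[nH]n2)cc(OC)c1OC` carries three. In a functional assay on MCF7 cells (Homo sapiens) for cytotoxicity, read by sulforhodamine B assay, with a stated time of 48 h, tested at 0.01 uM (a lower number here means a stronger effect, a higher number a weaker effect of the compound at the concentration tested), compound 1 gives 84%. In this assay compound 2 gives 89%. Compound 2 stands at a reading that, set against compound 1, differs only by an amount inside the usual scatter of repeated measurements, so the two are best read as equal within what this assay can resolve. Neither compound shows a strong effect at the concentration tested.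

Compound 3 `COc1ccc(-c2cc(/C=C/C(=O)c3ccc(N)cc3)[nH]n2)cc1OC` has not yet been measured in this assay. It differs from compound 2 in one place: hydrogen in place of methoxy on an aromatic carbon. A methoxy leaves an aromatic carbon of a six-membered aromatic ring of carbon only, ortho to a methoxy group and meta to a large group, and a hydrogen enters. Because compound 1 with 84% and compound 2 with 89% sit so close, a step from compound 2 to compound 3 of a number 3 percentage points lower from compound 2 to compound 3 (within the scatter) is expected, none beyond the scatter. Compound 3 is therefore estimated to give 86%, within 74% to 96%, in this assay.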

Compound 3, a percentage reported as activity, at one concentration (the size of the read-out at that concentration, not a potency): 89%
The estimate for compound 3 lay 3 percentage points below the measured number, within the range that was stated.
By their numbers in this assay, from the lowest: compounds 1, 2 and 3 (each within the scatter of the next).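

Compound 3 fills the gap between the other two, with one methoxy fewer than compound 2 and one more than compound 1, so each of its two neighbours can now be compared with it across a single change. On the aromatic carbon ortho to a methoxy group and meta to a large group, hydrogen in place of methoxy gives no change at the digits printed from compound 2 to compound 3 (within the scatter) in this assay, while at the neighbouring step, methoxy in place of hydrogen gives a number 5 percentage points higher from compound 1 to compound 3 (within the scatter), so neither single change separates the compounds at this one low concentration, and all three read as equal in this assay. Nothing at hand offers an explanation for this flat picture, and a single-concentration reading gives no potency.

On these data alone, what a hydroxyl group, an amine or a longer chain such as ethoxy would do on this same aromatic carbon stays open. Also open, as far as these compounds go, is whether compounds 1, 2 and 3 would still read alike at a concentration where the effect is strong enough for differences to appear.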